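The source may hold more compounds than are shown below. What is called first, only, known or untested is meant among the compounds shown, and "the series" means these compounds.

Measured compounds:
Compound 1 `COc1cc(O)c(C(=O)/C=C/c2ccc(OCc3cn(-c4ccc(Cl)cc4)nn3)c(OCc3cn(-c4ccc(Cl)cc4)nn3)c2)c(OC)c1`: > 100 ug/mL
Compound 2 `COc1cc(OC)c2c(=O)cc(-c3ccc(OCc4cn(-c5ccc(Cl)cc5)nn4)c(OC)c3)oc2c1`: > 100 ug/mL
Compound 3 `COc1cc(O)c(C(=O)/C=C/c2ccc(OCc3cn(-c4ccc(Cl)cc4)nn3)c(OC)c2)c(OC)c1`: > 100 ug/mL

All three values in an ADME assay on Huh-7 cells (Homo sapiens) for cytotoxicity, read by MTT assay, with a stated time of 72 h (a lower number here means that less compound is tolerated, a higher number that more compound is tolerated), are limits of the assay rather than numbers. Compound 3 gives > 100 ug/mL as a limit. Compound 1 gives > 100 ug/mL as a limit. Compound 2 gives > 100 ug/mL as a limit. The change 1-(4-chlorophenyl)-1H-1,2,3-triazol-4-yl in place of hydrogen on a saturated chain carbon bound to an oxygen on an aromatic ring therefore leaves a step that cannot be read: a step that the two limits leave unreadable from compound 3 to compound 1. The difference between the core of compound 2 and the core of compound 3 is not broken down here.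

Compound 4 `COc1cc(OC)c2c(=O)cc(-c3ccc(OCc4cn(-c5ccc(Cl)cc5)nn4)c(OCc4cn(-c5ccc(Cl)cc5)nn4)c3)oc2c1` has not yet been measured. It arises from compound 2 by the same change, (1-(4-chlorophenyl)-1H-1,2,3-triazol-4-yl in place of hydrogen on a saturated chain carbon bound to an oxygen on an aromatic ring). Because the limit of > 100 ug/mL in this assay, at which 3 of the 3 values shown sit, shows every value sitting at the same limit, the step from compound 2 to compound 4 is expected to be about a step that the limit leaves unreadable from compound 2 to compound 4. Compound 4 is therefore estimated at 120 ug/mL in this assay, ranging from 60 ug/mL to 250 ug/mL.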

Compound 4, half-maximal cytotoxic concentration: > 100 ug/mL
Compound 4 ended at the assay's limit (the forecaster's own chance of this, stated with the estimate: 80%); the middle value does not contradict the limit.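

In this assay compound 4 gives > 100 ug/mL, which is a limit. Compound 2 is also at a limit, and the step from it to compound 4 cannot be read. The compounds shown leave open the concentration at which any of them harms these cells.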